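The source may hold more compounds than are shown below. What is called first, only, known or untested is meant among the compounds shown, and "the series" means these compounds.

Of the compounds shown here, three sharing one core have been measured in an assay on Sf9 cells for inhibition of mitogen-activated protein kinase kinase kinase 14 variant S549D (Homo sapiens), with a stated time of 30 min, in the presence of a further agent that is not named here; a lower number here means a stronger inhibitor, a higher number a weaker inhibitor. Compound 1 `CCc1ccc2ncn(-c3ccnc(N)n3)c2c1` gives 79400 nM. Compound 2 `CC(=O)NCCCc1ccc2ncn(-c3ccnc(N)n3)c2c1` reaches only a limit of the assay, > 100000 nM. The step of an at least 1.2-fold higher number from compound 1 to compound 2 (0.10 log units; that floor lies within the scatter) is accordingly bounded by that limit (the limit of > 100000 nM in this assay, at which 1 of the 3 values shown sits). Compound 3 `C=Cc1cc(C#Cc2ccc3ncn(-c4ccnc(N)n4)c3c2)ccn1` gives 20000 nM, the lowest of the two numbers actually read, with compound 1 the nearest at a higher number that lies beyond the scatter. Compound 4 `C#Cc1cc(C#Cc2ccc3ncn(-c4ccnc(N)n4)c3c2)ccn1` differs from compound 3 by ethynyl in place of vinyl on an aromatic carbon. Within the data shown here, no measured step touches that part of the molecule, and the single step that has been measured stays within the scatter. Compound 4 is therefore expected to show no step beyond the scatter, no change at the digits printed from compound 3 to compound 4 (within the scatter), in this assay. The estimate for compound 4 is 20000 nM, with a range from 7000 nM to 60000 nM.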

Compound 4, half-maximal inhibitory concentration: 31600 nM
Beside the measured number, compound 4's estimate is 1.6-fold (0.20 log units) below it, and the stated range covers the measured number.
By their numbers in this assay, from the lowest: compounds 3 and 4 (each within the scatter of the next); then compound 1. At a limit, above all of these: compound 2.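

In this assay, ethynyl in place of vinyl on an aromatic carbon, next to the ring nitrogen, gives a 1.6-fold higher number from compound 3 to compound 4 (0.20 log units; within the scatter). Among these compounds, this is the only measured step at this position, and it shows that the assay does not separate a double bond from a triple bond in this two-carbon group. Nothing shown here bears on the reason for this result. As far as these compounds go, whether an amine, a carboxylic acid or a longer chain at this place would move the number beyond the scatter stays open. So does the outcome of having plain hydrogen there.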